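This account rests on a few compounds, and the source may have more. Where it says the series, first, only, none or still open, it means among the compounds named here.

Working notes on the series. Compound 1 `O=C(Nc1ccccc1)c1cnc(NCc2c(F)ccc3c2CCO3)n2cnnc12` reads < 1000 nM in a physicochemical assay for solubility, read by LC-MS, in phosphate buffer, with a stated time of 24 h, at pH 7.4 (on this read-out higher numbers stand for higher solubility and lower numbers for lower solubility), as a limit and not a number. Compound 2 `Cc1ncccc1-c1cnc(NCc2c(F)ccc3c2CCO3)c2nn(CC#N)c(=O)n12` gives 4000 nM and compound 3 `Cc1nccn1-c1cnc(NCc2c(F)ccc3c2CCO3)c2cn[nH]c(=O)c12` gives 7000 nM and these two numbers lie within the scatter of each other. Compound 4 `Cc1ncccc1-c1cnc(NCc2c(F)ccc3c2CCO3)c2n[nH]c(=O)n12` has not yet been measured. Compared with compound 2 it carries hydrogen in place of cyanomethyl on an aromatic nitrogen. For the measured compounds named here, no measured pair shows this change, so no step beyond the scatter is expected in this assay in either direction. The expected change is a 1.3-fold higher number from compound 2 to compound 4 (0.10 log units; within the scatter) and it stays within the scatter. Compound 4 is estimated at 5000 nM with an expected range of 1500 nM to 16000 nM in this read-out.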

Compound 4, solubility: < 2000 nM
Compound 4 ended at the assay's limit; the forecaster's own chance of this, stated with the estimate: 15%; at least 2.5-fold (0.39 log units) between middle value and limit.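

Hydrogen in place of cyanomethyl on an aromatic nitrogen gives the first step read at this position in this assay, with an at least 2.0-fold lower number from compound 2 to compound 4 (0.30 log units; that floor lies within the scatter) as its result. This change therefore brings no rise in the number, and the printed floor alone does not carry the step beyond the scatter. Compound 4 stands as a limit of the assay and not a number: the limit of < 2000 nM in this assay, at which 1 of the 4 values shown sits.

From the compounds shown here alone, how far compound 4 lies under that limit remains open, and with it the true size of the step. Also open, going by these compounds, is how a methyl, a longer nitrile chain or a chain ending in an amine would read on this nitrogen.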